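Acylguanidine Swapped for a Piperazine Amide

The source may hold more compounds than are shown below. What is called first, only, known or untested is meant among the compounds shown, and "the series" means these compounds.

Compound 1 `COc1ccc(-c2nc(/N=C(\N)N(C)C)sc2-c2ccc(OC)cc2)cc1` gives 37 nM in a functional assay with Oryctolagus cuniculus as the target; on this read-out lower numbers stand for stronger inhibition and higher numbers for weaker inhibition. Compound 2 `COc1ccc(-c2nc(C(=O)N=C(N)N)sc2-c2ccc(OC)cc2)cc1` reaches only a limit, > 100 nM in this assay, so its true number is not known. Going by the values given here, the only measured step, an at least 2.7-fold higher number from compound 1 to compound 2 (0.43 log units; beyond the scatter), is a weakening that ends at the limit of > 100 nM in this assay, at which 1 of the 2 values shown sits. Compound 3 `COc1ccc(-c2nc(C(=O)N3CCNC(CCO)C3)sc2-c2ccc(OC)cc2)cc1` differs from compound 2 by a group of 9 heavy atoms (6 carbon, 2 nitrogen, 1 oxygen; one six-membered non-aromatic ring with 2 hetero atoms) in place of a group of 4 heavy atoms (1 carbon, 3 nitrogen; no ring), on a carbonyl carbon. Among the compounds with values here, no measured step covers this change, so the expectation rests on compound 2 standing at the limit. Compound 3 is expected to stay weak, a step that the limit leaves unreadable from compound 2 to compound 3. Compound 3 is therefore estimated at 400 nM, with a range from 100 nM to 3000 nM.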

Compound 3, half-maximal inhibitory concentration: > 1000 nM
Compound 3: a limit, no number; the forecaster's own chance of this, stated with the estimate: 60%; middle value at least 2.5-fold (0.39 log units) from the limit.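

Compound 2 and compound 3 both end at limits in this assay, and the step between them cannot be read. From the compounds shown here alone, whether the 3-(2-hydroxyethyl)piperazin-1-yl group of compound 3 gives weaker or stronger inhibition than the group it replaces in compound 2 stays open.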